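The source may report more compounds than this note shows. Statements on the series, on what has been measured and on what is new or still open speak of the compounds shown alone.

Measured compounds so far:
Compound 1, `Cc1nc(N2CCC(N3CCOC3=O)CC2)nc2ccc(NC(=O)/C=C/c3ccc(OC(F)(F)F)cc3)cc12`; in an assay on CHO-K1 cells for displacement of a labelled ligand from melanin-concentrating hormone receptor 1 (Homo sapiens), read by scintillation proximity assay, with a stated time of 2 h (on this read-out higher numbers stand for weaker inhibition and lower numbers for stronger inhibition), compound 1 gives 41 nM.
Compound 2, `Cc1nc(N2CCC(N3CCCS3(=O)=O)CC2)nc2ccc(NC(=O)/C=C/c3ccc(OC(F)(F)F)cc3)cc12`; in this assay compound 2 gives 4 nM.

Compound 2 holds the lowest of the two numbers; its nearest neighbour is compound 1, and the step of a 10-fold lower number from compound 1 to compound 2 (1.01 log units; beyond the scatter) lies beyond the scatter. Compound 3, `Cc1nc(N2CCC(N3CCN(C)C3=O)CC2)nc2ccc(NC(=O)/C=C/c3ccc(OC(F)(F)F)cc3)cc12`, differs from compound 2 in one place: a group of 7 heavy atoms (4 carbon, 2 nitrogen, 1 oxygen; one five-membered non-aromatic ring with 2 hetero atoms) in place of a group of 7 heavy atoms (3 carbon, 1 nitrogen, 2 oxygen, 1 sulfur; one five-membered non-aromatic ring with 2 hetero atoms), on a saturated ring carbon. Among the compounds with values here, the only measured step that bears on this change is the one from compound 1 to compound 2, in which a five-membered ring holding a carbonyl and two hetero atoms gave way to the sulfur-containing ring, and that step was large, a 10-fold lower number from compound 1 to compound 2 (1.01 log units; beyond the scatter). Compound 3 moves back to a five-membered ring with a carbonyl and two hetero atoms, now with a methyl on the second nitrogen, so the expectation is a step upward in this assay, though not necessarily all the way back to compound 1. The estimated step is a 6.3-fold higher number from compound 2 to compound 3 (0.80 log units; beyond the scatter). Compound 3 is therefore expected to give about 25 nM, with a range from 7 nM to 90 nM.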

Compound 3, half-maximal inhibitory concentration: 21 nM
For compound 3 the middle estimate is 1.2-fold (0.08 log units) above the measured one, and the stated range covers the measured number.
By their numbers in this assay, from the lowest: compound 2; then compounds 3 and 1 (each within the scatter of the next).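

In this assay, the exchange of the sulfur-containing ring for 3-methyl-2-oxoimidazolidin-1-yl shows a cost at this saturated ring carbon even though the heavy-atom count stays the same: a 5.3-fold higher number from compound 2 to compound 3 (0.72 log units; beyond the scatter). Size counted in heavy atoms therefore does not settle the outcome among these groups, and the two rings that carry a carbonyl cannot be told apart, since 3-methyl-2-oxoimidazolidin-1-yl in place of 2-oxo-1,3-oxazolidin-3-yl gives a 2.0-fold lower number from compound 1 to compound 3 (0.29 log units; within the scatter). Among the three compounds, only compound 2 stands apart from the others by more than the scatter, but nothing at hand explains that gap.

Going by these compounds, it remains open whether the lower number of compound 2 depends on the closed ring, as an open-chain methanesulfonamide on the same carbon would test, or on ring size, as a six-membered ring holding the same sulfur group would test. On these data alone, it is equally open what the methyl contributes in compound 3, a question that the parent 2-oxoimidazolidin-1-yl, with a hydrogen on that nitrogen, or an N-ethyl analogue could address.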